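A Dichlorophenyl Swap After a Step Within the Scatter

A few compounds are considered here, and "the series" means these few. Any claim that something is new, unique, unknown or untested is made for them only; others in the source may bear on it.

In a functional assay, read by spectrophotometry, tested at 100 uM (a higher number here means a weaker inhibitor, a lower number a stronger inhibitor), compound 1 `CN(C)c1ccc(/C=C/C(=O)c2cccc(NC(=O)c3cc(-c4ccncc4)n[nH]3)c2)cc1` gives 41900 nM. Compound 2 `COc1ccccc1/C=C/C(=O)c1cccc(NC(=O)c2cc(-c3ccncc3)n[nH]2)c1` gives 41700 nM, which leaves the two level within the usual scatter. Compound 3 `O=C(/C=C/c1ccc(Cl)cc1Cl)c1cccc(NC(=O)c2cc(-c3ccncc3)n[nH]2)c1` carries 2,4-dichlorophenyl in place of 2-methoxyphenyl on a double-bonded chain carbon bound to a double-bonded chain carbon. Among the measured compounds shown here, one measured step bears on this place: a 1.0-fold lower number from compound 1 to compound 2 (0.00 log units; within the scatter), a change within the scatter. That single step is thin evidence, but it gives no reason to expect a move in this assay beyond the scatter. The expected step is a 1.0-fold lower number from compound 2 to compound 3 (0.02 log units; within the scatter). The estimate for compound 3 is 40000 nM, within a range of 18000 nM to 90000 nM.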

Compound 3, half-maximal inhibitory concentration: 35000 nM
Estimate against measurement, compound 3: 1.1-fold (0.06 log units) above; measured number inside the range.
By their numbers in this assay, from the lowest: compounds 3, 2 and 1 (each within the scatter of the next).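

In this assay, 2,4-dichlorophenyl on a double-bonded chain carbon bound to a double-bonded chain carbon gives a 1.2-fold lower number from compound 2 to compound 3 (0.08 log units; within the scatter), and a 1.2-fold lower number from compound 1 to compound 3 (0.08 log units; within the scatter). All three groups at this place now stand level, even though the entering group carries two chlorine atoms and counts no hydrogen-bond acceptor. Nothing measured here explains this level result.

Still open, as far as these compounds go, is whether a group other than a substituted phenyl at this place, such as an amine or a carboxylic acid, would move the number beyond the scatter. Plain unsubstituted phenyl also remains untested among the compounds shown.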